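The source may hold more compounds than are shown below. What is called first, only, known or untested is meant among the compounds shown, and "the series" means these compounds.

In a functional assay on HCT-116 cells (Homo sapiens) for antiproliferative activity, read by MTT assay, with a stated time of 24 h (a higher number here means a weaker inhibitor, a lower number a stronger inhibitor), compound 1 (`COc1ccc(C(=O)/C=C/c2ccc(N(C)C)cc2)c2c1C=CC(C)(C)O2`) gives 1920 nM. Compound 2 (`COc1ccc(C(=O)/C=C/c2ccc(-n3ccnc3)cc2)c2c1C=CC(C)(C)O2`) gives > 10000 nM, which is a limit of the assay and not a number. That places compound 2 at the limit of > 10000 nM in this assay, at which 1 of the 2 values shown sits. Among the compounds with values here, the one measured step that bears on the next change is an at least 5.2-fold higher number from compound 1 to compound 2 (0.71 log units; beyond the scatter), made on the same aromatic carbon and beyond the scatter. It shows that a swap at this carbon can move the number in this assay, but it says nothing directly about the new group, and its true size is open on one side. Compound 3 (`COc1ccc(C(=O)/C=C/c2ccc(C(F)(F)F)cc2)c2c1C=CC(C)(C)O2`) carries trifluoromethyl in place of 1H-imidazol-1-yl on that aromatic carbon: trifluoromethyl in place of 1H-imidazol-1-yl on an aromatic carbon. Any readable number for compound 3 would have to lie under the limit, so a modest move toward stronger inhibition is expected, though a second limit remains possible. The expected change is an at least 2.0-fold lower number from compound 2 to compound 3 (0.30 log units; that floor lies within the scatter). For compound 3 the estimate is 5000 nM, with an expected range from 1500 nM to 10000 nM.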

Compound 3, half-maximal inhibitory concentration: > 10000 nM
Compound 3 gave a limit, no number; the forecaster's own chance of this, stated with the estimate: 35%; middle value at least 2.0-fold (0.30 log units) away from the limit.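

In this assay, trifluoromethyl in place of dimethylamino on the aromatic carbon gives an at least 5.2-fold higher number from compound 1 to compound 3 (0.71 log units; beyond the scatter), so a second, quite different replacement of dimethylamino also ends at the limit of the assay rather than at a number. The step between compound 2 and compound 3 cannot be read, as both values are limits, and no order can be given between 1H-imidazol-1-yl and trifluoromethyl. Of the three groups shown on this carbon, only dimethylamino gives a readable number, and the other two sit at the same limit: the limit of > 10000 nM in this assay, at which 2 of the 3 values shown sit.

As far as these compounds go, how far compound 2 and compound 3 actually lie from that limit remains open. Also open, from the compounds shown here alone, is whether another amine on this carbon, such as methylamino or a plain amino group, or a methoxy group, would give a readable number.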